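A Fluoro Group on the Aminophenyl Ring of Compound 3

This account rests on a few compounds, and the source may have more. Where it says the series, first, only, none or still open, it means among the compounds named here.

In a functional assay on blood (Homo sapiens), with a stated time of 60 min, in the presence of a further agent that is not named here (a lower number here means that less compound is needed, a higher number that more compound is needed for the effect), compound 1 (`O=C(Oc1ccccc1)C1(S(=O)(=O)c2ccc(Oc3ccc(OC(F)(F)F)cc3)cc2)CCC2(CCNCC2)C1`), with phenoxycarbonyl on a saturated ring carbon, gives 900 nM. Compound 3 (`Nc1ccccc1NC(=O)C1(S(=O)(=O)c2ccc(Oc3ccc(OC(F)(F)F)cc3)cc2)CCC2(CCNCC2)C1`), with (2-aminophenyl)carbamoyl on that carbon, gives 900 nM, level with compound 1. Compound 2 (`O=S(=O)(c1ccc(Oc2ccc(OC(F)(F)F)cc2)cc1)C1(CO)CCC2(CCNCC2)C1`), with hydroxymethyl there, gives > 15000 nM, and this value is a limit of the assay.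

Compound 4 (`Nc1ccc(F)cc1NC(=O)C1(S(=O)(=O)c2ccc(Oc3ccc(OC(F)(F)F)cc3)cc2)CCC2(CCNCC2)C1`) departs from compound 3 by one change, fluoro in place of hydrogen on an aromatic carbon, para to an amino group. Among the compounds with values here, no measured step touches this ring directly. The nearest is the exchange of phenoxy for (2-aminophenyl)amino on the carbonyl carbon, which gives no change at the digits printed from compound 1 to compound 3 (within the scatter), inside the scatter. The large steps arise only where hydroxymethyl and a carbonyl-bearing group replace each other: an at least 16-fold higher number from compound 1 to compound 2 (1.22 log units; beyond the scatter) and an at least 16-fold lower number from compound 2 to compound 3 (1.22 log units; beyond the scatter). Compound 4 keeps the carbonyl group, so those steps offer little guidance here, and a single fluoro is not expected to move the number beyond the scatter in either direction. The expected step is a 1.1-fold lower number from compound 3 to compound 4 (0.05 log units; within the scatter). For compound 4 the estimate is 800 nM, with an expected range of 300 nM to 2200 nM.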

Compound 4, half-maximal effective concentration: > 15000 nM
Compound 4 gave a limit, no number (the forecaster's own chance of this, stated with the estimate: 5%); at least 18-fold (1.27 log units) between middle value and limit.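

In this assay, the ring of the (2-aminophenyl)carbamoyl group proves sensitive to a very small change: a single fluoro, para to an amino group, gives an at least 16-fold higher number from compound 3 to compound 4 (1.22 log units; beyond the scatter), whereas the earlier large steps arose only where hydroxymethyl and a carbonyl-bearing group replaced each other. Keeping the carbonyl therefore does not by itself hold the number, for the exchange of phenoxy for (2-amino-5-fluorophenyl)amino gives an at least 16-fold higher number from compound 1 to compound 4 (1.22 log units; beyond the scatter), while the step from compound 2 to compound 4 cannot be read, both values being limits. Compound 4 stands at > 15000 nM, which is a limit of the assay, so the full size of the loss stays unknown: the limit of > 15000 nM in this assay, at which 2 of the 4 values shown sit.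

The compounds shown leave open whether this loss belongs to fluoro itself or would also follow from chloro, methyl or methoxy on the same aromatic carbon. They also leave open whether fluoro on another carbon of this ring would give a number in the range of compound 3, which gives 900 nM.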